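The source may report more compounds than this note shows. Statements on the series, on what has been measured and on what is new or still open speak of the compounds shown alone.

Working notes on a small series built on the shared core of compound 1 `Cc1cc(NC(=O)Nc2ccc(C(=O)O)cc2)c2ccccc2n1`. In an ADME assay on HepG2 cells (Homo sapiens) for cytotoxicity, with a stated time of 72 h (a higher number here means that more compound is needed for the effect, a lower number that less compound is needed), compound 1 gives > 25000 nM, which is a limit of the assay rather than a number. Compound 2 `COc1ccc(NC(=O)Nc2cc(C)nc3ccccc23)cc1F` likewise returns > 25000 nM in this assay, again only a limit. Compound 3 `Cc1cc(NC(=O)Nc2cc(F)ccc2F)c2ccccc2n1` sits at > 25000 nM in this assay, also a limit. Compound 1 therefore cannot be placed relative to compounds 2 and 3: all three stand at the limit of > 25000 nM in this assay, at which 3 of the 3 values shown sit, and no ordering among them can be read from the values shown.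

Compound 4 `Cc1cc(NC(=O)Nc2ccc(O)cc2)c2ccccc2n1` is the next member to be measured. Relative to compound 1 the change is hydroxy in place of carboxy on an aromatic carbon. Among the compounds with values here, no step between measured compounds is available to calibrate this change, and the three values on hand give no case in which a change of substituent moved the half-maximal effective concentration away from its limit. The expectation for compound 4 in this assay is therefore no step beyond the usual scatter, with the result most likely again reported only as a limit. The estimated value for compound 4 is 35000 nM, with a range from 12000 nM to 100000 nM. The step that the limit leaves unreadable from compound 1 to compound 4 is expected to be essentially none.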

Compound 4, half-maximal effective concentration: > 25000 nM
Compound 4: a limit, no number; the forecaster's own chance of this, stated with the estimate: 80%; the middle value lies beyond the limit too.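

Compound 1 and compound 4 both return only a limit in this assay, so no step can be read for hydroxy in place of carboxy, and the series stands at one value: the limit of > 25000 nM in this assay, at which 4 of the 4 values shown sit.

The compounds shown leave open whether any change on the shared core gives a readable half-maximal effective concentration in this assay.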